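Removing a Fluorine from the Fused Ring of Compound 3

The source may report more compounds than this note shows. Statements on the series, on what has been measured and on what is new or still open speak of the compounds shown alone.

Of the compounds shown here, three sharing one core have been tested in a functional assay on CHO cells for agonist activity at Melanocortin receptor 4 (Homo sapiens), read by a luciferase reporter, with a stated time of 4 h; a higher number here means that more compound is needed for the effect, a lower number that less compound is needed. Compound 1 `CC(C)N(C(=O)CN1C=CN(c2ccccc2)C(=O)C(Cc2n[nH]c3ccccc23)C1=O)c1ccccc1` gives 3240 nM. Within the data shown here, compound 2 `CC(C)N(C(=O)CN1C=CN(c2ccccc2)C(=O)C(Cc2n[nH]c3ccccc23)C1=O)c1ccc(F)cc1` gives 282 nM; the single change between them, an 11-fold lower number from compound 1 to compound 2 (1.06 log units; beyond the scatter), is the only measured step in this set. Compound 3 `COc1ccc(N(C(=O)CN2C=CN(c3ccccc3)C(=O)C(Cc3n[nH]c4cc(F)ccc34)C2=O)C(C)C)cc1` gives 355 nM, which places it second highest of the three numbers: it lies nearest to compound 2, within the usual scatter, and furthest from compound 1, beyond the scatter.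

Compound 4 `COc1ccc(N(C(=O)CN2C=CN(c3ccccc3)C(=O)C(Cc3n[nH]c4ccccc34)C2=O)C(C)C)cc1` differs from compound 3 in one place: hydrogen in place of fluoro on an aromatic carbon. Among the measured compounds shown here, the only measured step concerns a fluoro added on an aromatic carbon of a different ring, and it was large in the direction of a lower number; here the fluoro is removed from the six-membered ring of the fused two-ring system, so a step toward a higher number of modest size, around the edge of the scatter, is expected, as a 1.8-fold higher number from compound 3 to compound 4 (0.26 log units; within the scatter). Compound 4 is therefore estimated at 650 nM, within a range from 200 nM to 2200 nM.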

Compound 4, half-maximal effective concentration: 708 nM
Beside the measured number, compound 4's estimate is 1.1-fold (0.04 log units) below it; the measured number falls inside the stated range.
By their numbers in this assay, from the lowest: compounds 2, 3 and 4 (each within the scatter of the next, the first and the last beyond it); then compound 1.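

In this assay, hydrogen in place of fluoro on the six-membered ring of the fused system gives a 2.0-fold higher number from compound 3 to compound 4 (0.30 log units; within the scatter), so the fluoro at this position makes no difference that can be told from the scatter. At the position that separates compound 1 from compound 2, methoxy in place of fluoro gives a 2.5-fold higher number from compound 2 to compound 4 (0.40 log units; beyond the scatter) and methoxy in place of hydrogen gives a 4.6-fold lower number from compound 1 to compound 4 (0.66 log units; beyond the scatter), which places methoxy between fluoro and hydrogen there. The effect of a fluoro on an aromatic carbon thus differs clearly between these two places: the same change on two cores in this assay, an 11-fold lower number (1.06 log units; beyond the scatter) from compound 1 to compound 2 and a 2.0-fold lower number (0.30 log units; within the scatter) from compound 4 to compound 3, 5.8-fold (0.76 log units) apart, beyond the scatter of two such steps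

Only hydrogen and fluoro are shown at this position of the fused ring system, so the effect of a chloro, a nitrile or an amine there remains open. Also open, from the compounds shown here alone, is how the fluoro on the fused ring system behaves when the other position carries fluoro rather than methoxy.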